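Swapping 3-fluorophenyl for 4-methylphenyl at a solubility limit

This account rests on a few compounds, and the source may have more. Where it says the series, first, only, none or still open, it means among the compounds named here.

In a physicochemical assay for solubility, in phosphate buffer (a lower number here means a less soluble compound, a higher number a more soluble compound), compound 3 (`Cc1cc(N[C@H](CCCCNCc2cccc(F)c2)C(=O)NO)cc(C)c1F`) gives > 5 ug/mL as a limit, not a number. Compound 1 (`Cc1cc(N[C@H](CCCCN)C(=O)NO)cc(C)c1F`) gives > 5 ug/mL as a limit too. Compound 2 (`Cc1cc(CNCCCC[C@@H](Nc2cc(C)c(F)c(C)c2)C(=O)NO)ccc1F`) also gives > 5 ug/mL as a limit. All the evidence is thus the limit of > 5 ug/mL in this assay, at which 3 of the 3 values shown sit, with no exact figure. Compound 4 (`Cc1ccc(CNCCCC[C@@H](Nc2cc(C)c(F)c(C)c2)C(=O)NO)cc1`) carries 4-methylphenyl in place of 3-fluorophenyl on a saturated chain carbon bound to an amine nitrogen relative to compound 3. Among the compounds with values here, three measured steps bear on this, a step that the two limits leave unreadable from compound 1 to compound 2 and a step that the two limits leave unreadable from compound 1 to compound 3 and a step that the two limits leave unreadable from compound 2 to compound 3 and none has a readable size. So no change beyond the scatter, in either direction, is expected in this assay here. The expected step is a step that the limit leaves unreadable from compound 3 to compound 4 with no direction favoured. For compound 4 the estimated solubility is 8 ug/mL with an expected range from 4 ug/mL to 25 ug/mL and another limit is likely.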

Compound 4, solubility: > 5 ug/mL
Compound 4: no number, only a limit (the forecaster's own chance of this, stated with the estimate: 80%); the middle value does not contradict the limit.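

No step from compound 1, compound 2 or compound 3 to compound 4 can be read in this assay, because every result is a limit, not a number: the limit of > 5 ug/mL in this assay, at which 4 of the 4 values shown sit.

Going by these compounds, whether these compounds truly differ in this assay, and whether 4-methylphenyl in place of 3-fluorophenyl changes anything, stays open.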